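Working notes: methylsulfanyl in place of fluoro on compound 1

The compounds below may be only part of what the source reports. "The series", "measured", "known", "first", "only" and "open" are said of these compounds alone.

Measured so far:
compound 1 `COc1cccc(Nc2nc(F)nc3[nH]cnc23)c1` — 1000 nM
compound 2 `Clc1cccc(Nc2nc(Cl)nc3[nH]cnc23)c1` — 3900 nM

In an assay for inhibition of cytokinin dehydrogenase 2 (Arabidopsis thaliana) (a higher number here means a weaker inhibitor, a lower number a stronger inhibitor), compound 1 gives 1000 nM, the lowest of the two numbers measured. Compound 2 gives 3900 nM, a higher number that lies beyond the scatter. Going by the values given here, no step between measured compounds that differ in a single place is available, so nothing known anchors the change to come.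

Compound 3 `COc1cccc(Nc2nc(SC)nc3[nH]cnc23)c1` differs from compound 1 by methylsulfanyl in place of fluoro on an aromatic carbon. A step from compound 1 to compound 3 of a 1.5-fold higher number from compound 1 to compound 3 (0.18 log units; within the scatter) is expected, a modest upward move, though a result within the scatter would not surprise. For compound 3 the estimate in this assay is 1500 nM, with a range from 400 nM to 6000 nM.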

Compound 3, half-maximal inhibitory concentration: > 100000 nM
Compound 3 was reported as a limit (the forecaster's own chance of this, stated with the estimate: 5%); middle value at least 66-fold (1.82 log units) away from the limit.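

At this aromatic carbon between two ring nitrogen atoms, methylsulfanyl in place of fluoro gives, in this assay, an at least 100-fold higher number from compound 1 to compound 3 (2.00 log units; beyond the scatter), the only single-place step shown: this position is not indifferent to the group it carries. Compound 3 gives > 100000 nM, a limit of the assay and not a number: the limit of > 100000 nM in this assay, at which 1 of the 3 values shown sits.

Whether the sulfur atom, the added methyl or the loss of fluoro accounts for this step stays open. Also open, as far as these compounds go, is how an amine or a hydroxyl at the same carbon would compare with fluoro on the core of compound 1.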